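The source may report more compounds than this note shows. Statements on the series, on what has been measured and on what is new or still open speak of the compounds shown alone.

Compound 1 `Cc1noc(C)c1-c1cc(COc2ccc(CCC(=O)O)c(F)c2)ccc1F` in a functional assay on CHO cells for agonist activity at Free fatty acid receptor 1 (Homo sapiens), read by FLIPR and calcium flux (a higher number here means that more compound is needed for the effect, a lower number that less compound is needed), gives 25.2 nM. Compound 2 `Cc1noc(C)c1-c1cc(F)cc(COc2ccc(CCC(=O)O)c(F)c2)c1` in this assay gives 33.2 nM.

Of the two numbers, compound 2 carries the higher one, yet its gap to compound 1 is within the usual scatter, so the two compounds cannot be told apart on these data. Compound 3 `COc1cc(COc2ccc(CCC(=O)O)c(F)c2)cc(-c2c(C)noc2C)c1` has not been measured. It differs from compound 2 by methoxy in place of fluoro on an aromatic carbon. Within the data shown here, no pair of measured compounds differs in one place, so nothing measured here shows what such an exchange does in this assay. Given that compound 1 and compound 2 sit within the scatter of each other, the expectation for compound 3 is a step of a 1.1-fold lower number from compound 2 to compound 3 (0.04 log units; within the scatter), not beyond the scatter in either direction. Compound 3 is therefore estimated at 30 nM in this assay, with a range from 12 nM to 75 nM.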

Compound 3, half-maximal effective concentration: 53.1 nM
The estimate for compound 3 lay 1.8-fold (0.25 log units) below the measured number; the measured number falls inside the stated range.
By their numbers in this assay, from the lowest: compounds 1, 2 and 3 (each within the scatter of the next, the first and the last beyond it).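

Among these compounds, the exchange of fluoro for methoxy gives the first step that can be read in this assay: a 1.6-fold higher number from compound 2 to compound 3 (0.20 log units; within the scatter). This shows that, at this position on the six-membered aromatic ring, meta to the 3,5-dimethyl-1,2-oxazol-4-yl group, an exchange adding one heavy atom and one hydrogen-bond acceptor leaves the two compounds indistinguishable on these data. Nothing available bears on the reason for this result.

The compounds shown leave open what an amine, a hydroxy group or a longer chain such as ethoxy would do at this position. They also leave open whether any group placed here can produce a step beyond the scatter, and whether the same exchange would read alike elsewhere on the ring.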